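The source may hold more compounds than are shown below. What is called first, only, known or untested is meant among the compounds shown, and "the series" means these compounds.

Measured so far:
compound 1 `CCCCCCN1C(=O)[C@H](Cc2ccc(-c3cccc(CN(CCCC)C(C)=O)c3)cc2)N(C)C(=O)[C@@H]1C` — 150 nM
compound 2 `CCCCCCN1C(=O)[C@H](Cc2ccc(-c3cccc(CN(CCCC)C(=O)OC)c3)cc2)N(C)C(=O)[C@@H]1C` — 8.9 nM
compound 3 `CCCCCCCCN1C(=O)[C@H](Cc2ccc(-c3cccc(CN(COC)C(C)=O)c3)cc2)N(C)C(=O)[C@@H]1C` — 9.7 nM

Of the compounds shown here, three have been tested in a functional assay for agonist activity at follicle-stimulating hormone receptor (Homo sapiens), read by a luciferase reporter; on this read-out lower numbers stand for an effect already at smaller amounts and higher numbers for an effect only at larger amounts of compound. Compound 1 gives 150 nM. Compound 2, which carries the change (methoxy in place of methyl on a carbonyl carbon), gives 8.9 nM, and the step is a 17-fold lower number from compound 1 to compound 2 (1.23 log units; beyond the scatter). Compound 3, built on a different core, gives 9.7 nM; its value and that of compound 2 lie within the usual scatter of each other, so no order between them can be read, while against compound 1 it stands well apart. How the core of compound 3 differs from that of compound 1 is not broken down here.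

Compound 4 `CCCCCCCCN1C(=O)[C@H](Cc2ccc(-c3cccc(CN(COC)C(=O)OC)c3)cc2)N(C)C(=O)[C@@H]1C` has not yet been measured. It carries the change (methoxy in place of methyl on a carbonyl carbon), the same change that turns compound 1 into compound 2, at a place described in the same words for both pairs. Within the scatter, compound 3 sits where compound 2 does, so the starting point is already a low number. Within the data shown here, the single precedent is large, but it was recorded once, on one core, and the groups on the amide-type nitrogen differ between the two pairs. Compound 4 is therefore expected to give a lower number than compound 3, by a step estimated at a 3.9-fold lower number from compound 3 to compound 4 (0.59 log units; beyond the scatter), resting on the size of a 17-fold lower number from compound 1 to compound 2 (1.23 log units; beyond the scatter) and tempered by the change of core. For compound 4 the value expected in this assay is 2.5 nM, with a range from 0.5 nM to 12 nM.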

Compound 4, half-maximal effective concentration: 1.8 nM
The estimate for compound 4 lay 1.4-fold (0.14 log units) above the measured number; measured number inside the range.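

Methoxy in place of methyl on a carbonyl carbon lowers the number again in this assay on the core of compound 3, and the new step is a 5.4-fold lower number from compound 3 to compound 4 (0.73 log units; beyond the scatter), so the direction of the change holds on both cores shown. The size of the step does not carry over unchanged, and the two steps differ by more than the scatter allows: the same change on two cores in this assay, a 17-fold lower number (1.23 log units; beyond the scatter) from compound 1 to compound 2 and a 5.4-fold lower number (0.73 log units; beyond the scatter) from compound 3 to compound 4, 3.1-fold (0.50 log units) apart, beyond the scatter of two such steps. This rests on two pairs only, which show that the step on one core is a poor guide to its exact size on another, but they do not show which feature of the cores goes with the smaller step, as the hexyl and octyl chains and the butyl and methoxymethyl groups all differ together between the pairs.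

The compounds shown leave open whether the larger or the smaller step would appear with an octyl chain paired with a butyl group, or with a hexyl chain paired with a methoxymethyl group, which would separate these two differences. They also leave open whether an ethoxy group or a dimethylamino group on the same carbonyl carbon would lower the number as methoxy does on these cores.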